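This account rests on a few compounds, and the source may have more. Where it says the series, first, only, none or still open, it means among the compounds named here.

Compound 2 `CCSc1nc(N)c2nc(O)n(Cc3ccccc3)c2n1` gives the lower of the two numbers in a functional assay on the whole organism for activation, with Mus musculus as the target (on this read-out higher numbers stand for an effect only at larger amounts of compound and lower numbers for an effect already at smaller amounts), at 0.1 mg/kg. Compound 1 `Cc1nc(N)c2nc(O)n(Cc3ccccc3)c2n1` gives 3 mg/kg, and the step of a 30-fold lower number from compound 1 to compound 2 (1.48 log units; beyond the scatter) is the only measured one. Compound 3 `CCCSc1nc(N)c2nc(O)n(Cc3ccccc3)c2n1` is made from compound 2 by methyl in place of hydrogen on a saturated chain carbon, two bonds along the chain from a sulfur. Among the compounds with values here, no measured step lengthens a chain in this way; the one known step swaps a whole group for another, so it says little here. The step of no change at the digits printed from compound 2 to compound 3 (within the scatter) is therefore expected to stay within the usual scatter. Compound 3 is estimated at 0.1 mg/kg in this assay, in a range from 0.03 mg/kg to 0.3 mg/kg.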

Compound 3, minimum effective dose: 0.1 mg/kg
Compound 3: middle estimate and measured number agree at the digits printed; low and high end bracket the measured number.
By their numbers in this assay, from the lowest: compounds 2 and 3 (each within the scatter of the next); then compound 1.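

In this assay, lengthening ethylsulfanyl to propylsulfanyl gives no change at the digits printed from compound 2 to compound 3 (within the scatter), so at this position the chain on the sulfur can carry one more carbon without the number leaving the scatter. The large difference from the methyl group also holds for the longer chain, with a 30-fold lower number from compound 1 to compound 3 (1.48 log units; beyond the scatter). No measurement here offers an explanation for either result.

The compounds shown do not reveal how far this tolerance extends, for example to a butylsulfanyl chain or a branched isopropylsulfanyl group. They also leave open whether the sulfur itself matters, which a butyl chain or an amine at the same place could test.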